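The source may hold more compounds than are shown below. What is called first, only, known or untested is meant among the compounds shown, and "the series" means these compounds.

In a functional assay on A549 cells (Homo sapiens) for antiproliferative activity, read by MTT assay, with a stated time of 6 days (on this read-out higher numbers stand for weaker inhibition and lower numbers for stronger inhibition), compound 1 `O=C1C=C[C@@H](OCc2ccccc2)[C@@H]([C@@H](COC(=O)/C=C/c2ccccc2)OCc2ccccc2)O1` gives 13300 nM and sits within the scatter of its two relatives: compound 2 `O=C1C=C[C@@H](OC(=O)c2ccccc2)[C@@H]([C@@H](COC(=O)c2ccccc2)OC(=O)c2ccccc2)O1` gives 21500 nM and compound 3 `CC(=O)OC[C@@H](OC(C)=O)[C@H]1OC(=O)C=C[C@H]1OC(C)=O` gives 12600 nM on the same read-out. Compound 4 `O=C1C=C[C@@H](OCc2ccccc2)[C@@H]([C@@H](CO)OCc2ccccc2)O1` is still unmeasured and differs from compound 1 by the change hydrogen in place of (2-phenylethenyl)carbonyl on an oxygen on a saturated carbon that puts hydrogen in place of (2-phenylethenyl)carbonyl on an oxygen on a saturated carbon. Going by the values given here, no measured pair shows this change alone, but compound 2 at 21500 nM and compound 3 at 12600 nM carry different groups on the shared core and stay within the scatter. In this assay the expected step of a 1.2-fold higher number from compound 1 to compound 4 (0.08 log units; within the scatter) is therefore a small one towards weaker inhibition, within the scatter. Compound 4 is estimated at 16000 nM with 6000 nM to 40000 nM as its likely range.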

Compound 4, half-maximal inhibitory concentration: 12900 nM
Estimate against measurement, compound 4: 1.2-fold (0.09 log units) above, within the range that was stated.
By their numbers in this assay, from the lowest: compounds 3, 4, 1 and 2 (each within the scatter of the next).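

Taking the (2-phenylethenyl)carbonyl off the oxygen on a saturated carbon, which turns the ((2-phenylethenyl)carbonyl)oxy group into hydroxy, gives the first comparison of compounds differing in one place in this assay. The step is a 1.0-fold lower number from compound 1 to compound 4 (0.01 log units; within the scatter) and so this large group can be replaced by hydrogen with no change that this assay can detect. No measurement is available that would explain this result.

On these data alone, whether an amine or a carboxylic acid at this position would shift the value remains open. So does the role of the other groups on the shared core, which stay the same in this pair.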